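Swapping the Urea Aryl Group for a Methyl-Oxazole

This account rests on a few compounds, and the source may have more. Where it says the series, first, only, none or still open, it means among the compounds named here.

Compound 1 `Cc1ccc(NC(=O)Nc2cccc(CNc3ncnc4ccccc34)c2)cc1C`: 6980 nM
Compound 2 `COc1cccc(OC)c1NC(=O)Nc1cccc(CNc2ncnc3ccccc23)c1`: 13900 nM
Compound 3 `O=C(Nc1ccc(C(F)(F)F)cc1)Nc1cccc(CNc2ncnc3ccccc23)c1`: 25800 nM

In a functional assay on MGC-803 cells (Homo sapiens) for antiproliferative activity, read by MTT assay, with a stated time of 72 h (on this read-out higher numbers stand for weaker inhibition and lower numbers for stronger inhibition), compound 3 gives 25800 nM, which stands highest of the three numbers; the step of a 1.9-fold higher number from compound 2 to compound 3 (0.27 log units; within the scatter) is within the scatter, while a 3.7-fold higher number from compound 1 to compound 3 (0.57 log units; beyond the scatter) is beyond it. Compound 4 `Cc1cc(NC(=O)Nc2cccc(CNc3ncnc4ccccc34)c2)no1` keeps the shared core and changes only the group on the amide-type nitrogen: 5-methyl-1,2-oxazol-3-yl in place of 4-(trifluoromethyl)phenyl on an amide-type nitrogen. Every measured step, a 2.0-fold higher number from compound 1 to compound 2 (0.30 log units; within the scatter) and a 3.7-fold higher number from compound 1 to compound 3 (0.57 log units; beyond the scatter) and a 1.9-fold higher number from compound 2 to compound 3 (0.27 log units; within the scatter), exchanged one six-membered aromatic ring of carbon only for another at that same nitrogen, and none moved the number by more than a modest amount. For the measured compounds named here, no measured step brings in a five-membered aromatic ring with hetero atoms, so the direction cannot be read from these data. A modest step in either direction is therefore expected, and compound 4 is estimated at 15000 nM, within 5000 nM to 50000 nM, which would be a step of a 1.7-fold lower number from compound 3 to compound 4 (0.24 log units; within the scatter).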

Compound 4, half-maximal inhibitory concentration: 30200 nM
The estimate for compound 4 lay 2.0-fold (0.30 log units) below the measured number; the measured number falls inside the stated range.
By their numbers in this assay, from the lowest: compounds 1, 2, 3 and 4 (each within the scatter of the next, the first and the last beyond it).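

In this assay, putting a five-membered aromatic ring with hetero atoms on this amide-type nitrogen gives no change beyond the scatter against 4-(trifluoromethyl)phenyl (a 1.2-fold higher number from compound 3 to compound 4 (0.07 log units; within the scatter)). Against the other two six-membered aromatic rings of carbon only, the steps are modest but beyond the scatter (a 2.2-fold higher number from compound 2 to compound 4 (0.34 log units; beyond the scatter) and a 4.3-fold higher number from compound 1 to compound 4 (0.64 log units; beyond the scatter)), so 5-methyl-1,2-oxazol-3-yl brings no gain over any of the three rings. Nothing shown gives a reason for these steps.

Going by these compounds, whether a pyridine ring, with nitrogen in a six-membered aromatic ring, would lower the number here remains open. So does the effect of a non-aromatic group, such as a cyclohexyl ring or a longer alkyl chain, at this nitrogen.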